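From propanoyl to benzoyl: estimating compound 4

The source may report more compounds than this note shows. Statements on the series, on what has been measured and on what is new or still open speak of the compounds shown alone.

- Compound 1 `CCCCNC(=O)N1Cc2c(NC(=O)c3ccc(C)cc3)nn(C(=O)c3ccccc3)c2C1`: 23200 nM
- Compound 2 `CC(=O)n1nc(NC(=O)c2ccccc2)c2c1CN(C(=O)c1ccccc1)C2`: 580 nM
- Compound 3 `CCC(=O)n1nc(NC(=O)c2ccccc2)c2c1CN(C(=O)c1ccccc1)C2`: 1060 nM

These three values come from a functional assay on HCT-116 cells (Homo sapiens) for cytotoxicity, read by sulforhodamine B assay, with a stated time of 48 h; a higher number here means a weaker inhibitor, a lower number a stronger inhibitor. In this assay, compound 3 gives 1060 nM, which lies within the usual scatter of compound 2 at 580 nM. Compound 1, at 23200 nM, shows a much higher number than either, so it is the weakest of the three.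

Compound 4 `O=C(Nc1nn(C(=O)c2ccccc2)c2c1CN(C(=O)c1ccccc1)C2)c1ccccc1` has not yet been measured. Its difference from compound 3 is phenyl in place of ethyl on a carbonyl carbon. Put simply, propanoyl becomes benzoyl, with phenyl in place of ethyl on a carbonyl carbon.

Two measurements bear on this change. The closest is a 1.8-fold higher number from compound 2 to compound 3 (0.26 log units; within the scatter), where methyl replaces hydrogen on a saturated chain carbon bound to a carbonyl carbon. That step is small, and it adds far less than the phenyl does. Compound 1 also carries a benzoyl at this place, and it gives 23200 nM, but it differs from compound 3 elsewhere too, so its value cannot be credited to benzoyl alone. Together these point, loosely, towards a higher number. The expected change is a 2.4-fold higher number from compound 3 to compound 4 (0.37 log units; beyond the scatter). For compound 4 the estimated value is 2500 nM, with an expected range from 700 nM to 9000 nM.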

Compound 4, half-maximal inhibitory concentration: 1400 nM
Compound 4: the middle estimate sits 1.8-fold (0.25 log units) above what was measured; measured number inside the range.
By their numbers in this assay, from the lowest: compounds 2, 3 and 4 (each within the scatter of the next, the first and the last beyond it); then compound 1.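

In this assay, the step from propanoyl to benzoyl is a 1.3-fold higher number from compound 3 to compound 4 (0.12 log units; within the scatter), so placing a six-membered aromatic ring of carbon only on this carbonyl carbon, where an ethyl stood, leaves the number inside the usual scatter. For the compounds shown here, this is the first sign that this place accepts a ring as well as a short chain, since the earlier compounds with this shared core carried only methyl and ethyl here. Measured against the smallest group of the three, the step is a 2.4-fold higher number from compound 2 to compound 4 (0.38 log units; beyond the scatter), a modest change and the only one among these three compounds at this place that lies beyond the scatter.

On these data alone, how a longer chain, or a phenyl ring bearing an amine or a carboxylic acid, would behave on this same carbonyl carbon stays open, so the three groups seen here cannot yet be read as a general trend for the position. Nothing in hand offers an independent measurement that could account for how close these numbers lie.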